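A smaller group on the shared core

The compounds below may be only part of what the source reports. "The series", "measured", "known", "first", "only" and "open" are said of these compounds alone.

In an ADME assay on microsomes from liver (Homo sapiens) for metabolic stability, read by LC-MS, using NADPH, with stated times of 5 min and 30 min, tested at 1 uM (on this read-out lower numbers stand for slow clearance and higher numbers for fast clearance), compound 1 `O=C1c2ccccc2CN1c1cnc(NCc2c(F)ccc3c2CCO3)n2cnnc12` gives 13 mL.min-1.g-1 while compound 2 `CN(C)Cc1ccc2c(c1)CN(c1cnc(NCc3c(F)ccc4c3CCO4)n3cnnc13)C2=O` gives 19 mL.min-1.g-1 and so stands level with it within the scatter. Going to compound 3 `CC1(C)CC(=O)N(c2cnc(NCc3c(F)ccc4c3CCO4)n3cnnc23)C1` the change is a group of 8 heavy atoms (6 carbon, 1 nitrogen, 1 oxygen; one five-membered non-aromatic ring with 1 hetero atom) in place of a group of 10 heavy atoms (8 carbon, 1 nitrogen, 1 oxygen; one five-membered non-aromatic ring with 1 hetero atom, one six-membered aromatic ring of carbon only), on an aromatic carbon and the rest of the molecule stays the same. Going by the values given here, the only measured step of a 1.5-fold higher number from compound 1 to compound 2 (0.16 log units; within the scatter) touches the group that leaves and stays within the scatter, so it gives no direction for compound 3. In this assay no change beyond the scatter is expected, and the estimated step is a 1.2-fold higher number from compound 1 to compound 3 (0.06 log units; within the scatter) for this swap. Compound 3 is expected at 15 mL.min-1.g-1 with a range from 7 mL.min-1.g-1 to 32 mL.min-1.g-1 around that estimate.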

Compound 3, intrinsic clearance in microsomes: 16 mL.min-1.g-1
Compound 3: the middle estimate sits 1.1-fold (0.03 log units) below what was measured; measured number inside the range.
By their numbers in this assay, from the lowest: compounds 1, 3 and 2 (each within the scatter of the next).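

In this assay, replacing the group that carries the six-membered aromatic ring with 4,4-dimethyl-2-oxopyrrolidin-1-yl gives a 1.2-fold higher number from compound 1 to compound 3 (0.09 log units; within the scatter). The earlier step only added a side group to that aromatic ring, whereas this one shows that the number stays within the scatter when the ring itself is gone from this position. Nothing measured here explains this result. Going by these compounds, whether a carboxylic acid or a longer chain at this place would shift the number beyond the scatter remains open, as does the separate contribution of the dimethyl part of the new ring.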